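Chloro to Nitro Exchange on Two Related Cores

The source may hold more compounds than are shown below. What is called first, only, known or untested is meant among the compounds shown, and "the series" means these compounds.

Compound 1 `O=C(Cn1c(=O)oc2cc(Cl)ccc21)Nc1ccccc1` and compound 2 `O=C(Cn1c(=O)oc2cc([N+](=O)[O-])ccc21)Nc1ccccc1` share a core and differ by one exchange, (nitro in place of chloro on an aromatic carbon). In an ADME assay on RAW264.7 cells (Mus musculus) for cytotoxicity, read by MTT assay, with a stated time of 72 h, tested at 100 uM (on this read-out higher numbers stand for a stronger effect at the one concentration tested and lower numbers for a weaker effect), compound 1 gives 20.2%, and compound 2 gives 26.4%. The step between them, a number 6.2 percentage points higher from compound 1 to compound 2 (within the scatter), stays inside the range that repeated runs of this kind would cover, so the two values are best read as alike.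

Compound 3 `O=C(Cn1c(=O)oc2cc(Cl)ccc21)Nc1nc2ccc([N+](=O)[O-])cc2s1` carries the chloro group of compound 1 but a different amide partner; how its core differs from that of compound 1 is not broken down here. In this assay compound 3 gives 14.2%. Against compound 1 that gap lies within the scatter, while against compound 2 the gap is beyond it.

Compound 4 `O=C(Cn1c(=O)oc2cc([N+](=O)[O-])ccc21)Nc1nc2ccc([N+](=O)[O-])cc2s1` has not yet been measured. It stands to compound 3 as compound 2 stands to compound 1: the change is nitro in place of chloro on an aromatic carbon, and the place of the change is the same in words in both pairs, so it is the same change made on the second core. Among the compounds with values here, the only guide to its effect is the pair of compound 1 and compound 2, where a number 6.2 percentage points higher from compound 1 to compound 2 (within the scatter) was measured. Carrying that step over, compound 4 is expected to land at 19% in this assay, between 8% and 32%. The step this estimate implies, a number 4.8 percentage points higher from compound 3 to compound 4 (within the scatter), rests on one measured pair only, so the expectation is loose.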

Compound 4, a percentage reported as inhibition, at one concentration (the size of the read-out at that concentration, not a potency): 39%
Compound 4: the middle estimate sits 20 percentage points below what was measured; measured number above the stated range.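

On the second core, the exchange of chloro for nitro on an aromatic carbon gives a number 24.8 percentage points higher from compound 3 to compound 4 (beyond the scatter) in this assay, a step that repeated runs would not be expected to cover. The size of the step did not carry over from one core to the other: the same change on two cores in this assay, a number 6.2 percentage points higher (within the scatter) from compound 1 to compound 2 and a number 24.8 percentage points higher (beyond the scatter) from compound 3 to compound 4, 18.6 percentage points apart, beyond the scatter of two such steps. This shows that in this series the step measured on one core was a poor guide to the step on the other, but it rests on two pairs only and does not show why the two cores respond differently, or how the exchange would behave on any further core.

The compounds shown leave open whether the larger step is tied to the amide partner shared by compound 3 and compound 4, since only that partner and the plain phenyl amide of compound 1 and compound 2 appear here. They also leave open what an amine, a methoxy group or a carboxylic acid would give on the same aromatic carbon, and whether the gap between the two cores would hold at concentrations other than the single one tested.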